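Benzylamide variations on the guanidinobenzoyl-glycyl-aspartate series

A few compounds are considered here, and "the series" means these few. Any claim that something is new, unique, unknown or untested is made for them only; others in the source may bear on it.

Two measured compounds anchor this set. Compound 1 `N=C(N)Nc1cccc(C(=O)NCC(=O)N[C@@H](CC(=O)O)C(=O)Nc2ccccc2)c1` gives 13 nM in an assay on a protein complex for binding affinity to integrin alpha-5/beta-1 (Homo sapiens), read by ELISA, with a stated time of 1 h (a lower number here means a stronger inhibitor, a higher number a weaker inhibitor), which is the lowest of the two numbers to hand. For the measured compounds named here, compound 2 `N=C(N)Nc1cccc(C(=O)NCC(=O)N[C@@H](CC(=O)O)C(=O)NCc2ccc(Cl)cc2)c1` gives 48 nM in this assay, and the step of a 3.7-fold higher number from compound 1 to compound 2 (0.57 log units; beyond the scatter) is the only measured change bearing on the new compound: 4-chlorobenzyl in place of phenyl on an amide-type nitrogen raised the number beyond the scatter.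

Compound 3 `COc1ccc(CNC(=O)[C@H](CC(=O)O)NC(=O)CNC(=O)c2cccc(NC(=N)N)c2)cc1` has not yet been measured in this assay. Relative to compound 1 it carries 4-methoxybenzyl in place of phenyl on an amide-type nitrogen. The new group is again a substituted benzyl on the same amide-type nitrogen, so the step from compound 1 to compound 2 is the closest precedent; whether a methoxy substituent behaves like a chloro substituent is not shown by any pair here, so the uncertainty is wide. The expectation is a modest rise of the number, a 2.7-fold higher number from compound 1 to compound 3 (0.43 log units; beyond the scatter), with a range that still allows no change beyond the scatter. Compound 3 is therefore estimated at 35 nM in this assay, between 12 nM and 110 nM.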

Compound 3, half-maximal inhibitory concentration: 40 nM
Compound 3: middle estimate off by 1.1-fold (0.06 log units), on the low side, within the range that was stated.
By their numbers in this assay, from the lowest: compound 1; then compounds 3 and 2 (each within the scatter of the next).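

In this assay, a second substituted benzyl on the amide-type nitrogen also sits above the phenyl of compound 1 (a 3.1-fold higher number from compound 1 to compound 3 (0.49 log units; beyond the scatter)), so the earlier rise no longer rests on 4-chlorobenzyl alone, although two compounds are a narrow basis for any pattern. Methoxy in place of chloro on an aromatic carbon makes no difference that can be read (a 1.2-fold lower number from compound 2 to compound 3 (0.08 log units; within the scatter)), so compounds 2 and 3 stand level in this assay and neither substituent can be ranked against the other. No evidence at hand explains the gap between the phenyl and the two substituted benzyl groups, or the match between the two benzyl groups.

The compounds shown leave open how much of the step from phenyl belongs to the added carbon that carries the ring and how much to the ring substituent, since each substituted benzyl differs from phenyl in both respects. Unsubstituted benzyl and 4-methoxyphenyl on the same nitrogen would separate the two, and a carboxylic acid or an amine on the benzyl ring would test whether the level shared by compounds 2 and 3 extends beyond methoxy and chloro.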